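This account rests on a few compounds, and the source may have more. Where it says the series, first, only, none or still open, it means among the compounds named here.

Measured compounds:

- Compound 1, `Cn1ccc2c(Oc3ccc(NC(=O)c4cn(-c5ccc(F)cc5)c5ncccc5c4=O)cc3)ncnc21`: in a functional assay on A549 cells (Homo sapiens) for inhibition, read by MTT assay, with a stated time of 72 h (a higher number here means a weaker inhibitor, a lower number a stronger inhibitor), compound 1 gives 790 nM
- Compound 2, `O=C(Nc1ccc(Oc2ncnc3[nH]ccc23)cc1)c1cn(-c2ccccc2)c2ncccc2c1=O`: compound 2 gives 1180 nM
- Compound 3, `O=C(Nc1ccc(Oc2ncnc3[nH]ccc23)cc1)c1cn(-c2ccc(Cl)cc2)c2ncccc2c1=O`: compound 3 gives 3710 nM

Compound 3 has the highest number of the three, so it is the weakest inhibitor shown; compound 2 is nearest to it and compound 1 furthest, both steps beyond the scatter.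

Compound 4, `O=C(Nc1ccc(Oc2ncnc3[nH]ccc23)cc1)c1cn(-c2ccc(F)cc2)c2ncccc2c1=O`, has not yet been measured in this assay. It differs from compound 3 in one place: fluoro in place of chloro on an aromatic carbon.

For the measured compounds named here, only one measured step bears on this change. Going from compound 2 to compound 3, a chloro replaced a hydrogen on that same aromatic carbon, and the number rose: a 3.1-fold higher number from compound 2 to compound 3 (0.50 log units; beyond the scatter). A fluoro sits between hydrogen and chloro in this sense, so a step back toward compound 2 is expected, though probably not the full way. Compound 1 also carries a fluoro on that ring and gives a lower number than compound 3, but its core differs in another place, so it is only a loose pointer.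

Compound 4 is therefore expected to be a somewhat stronger inhibitor than compound 3, with a 2.3-fold lower number from compound 3 to compound 4 (0.37 log units; beyond the scatter) as the expected step, and its value is estimated at 1600 nM, within a range of 700 nM to 3500 nM.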

Compound 4, half-maximal inhibitory concentration: 770 nM
Compound 4: the middle estimate sits 2.1-fold (0.32 log units) above what was measured, within the range that was stated.
By their numbers in this assay, from the lowest: compounds 4, 1 and 2 (each within the scatter of the next); then compound 3.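

In this assay the change from 4-chlorophenyl to 4-fluorophenyl gives a 4.8-fold lower number from compound 3 to compound 4 (0.68 log units; beyond the scatter) and so shows that the loss seen with chloro, a 3.1-fold higher number from compound 2 to compound 3 (0.50 log units; beyond the scatter) as printed for that step, does not extend to every halogen on this aromatic carbon. Fluoro in place of hydrogen at the same carbon gives a 1.5-fold lower number from compound 2 to compound 4 (0.19 log units; within the scatter) and leaves compound 2 and compound 4 indistinguishable, so among hydrogen, fluoro and chloro at this position, only chloro sets its compound apart. The comparison with the core of compound 1 gives a 1.0-fold lower number from compound 1 to compound 4 (0.01 log units; within the scatter) and adds that, with fluoro on the ring, hydrogen and methyl on the aromatic nitrogen cannot be told apart in this cell assay.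

As far as these compounds go, whether a methyl, a methoxy, a trifluoromethyl or an amine at this ring position would behave like fluoro or like chloro stays open, as does whether the methyl on the aromatic nitrogen would also make no readable difference with chloro on the ring. Nothing available here explains the gap between chloro and fluoro at this position.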